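This account rests on a few compounds, and the source may have more. Where it says the series, first, only, none or still open, it means among the compounds named here.

Measured compounds:
- compound 1 `COc1ccc(/C=N/NC(=O)Nc2ccc(Oc3ccnc(-c4nncn4CCN(C)C)c3)c(F)c2)c(OC)c1OC`: 2020 nM in a functional assay on MKN-45 cells (Homo sapiens) for cytotoxicity, read by MTT assay, with a stated time of 72 h; on this read-out lower numbers stand for stronger inhibition and higher numbers for weaker inhibition
- compound 2 `CN(C)CCn1cnnc1-c1cc(Oc2ccc(NC(=O)N/N=C/c3ccc(F)cc3)cc2F)ccn1`: 1030 nM in this assay

Among the measured compounds shown here, compound 2 and compound 1 lie within the scatter of each other; the only measured step, a 2.0-fold lower number from compound 1 to compound 2 (0.29 log units; within the scatter), does not separate them. Compound 3 `CN(C)CCn1cnnc1-c1cc(Oc2ccc(NC(=O)N/N=C/c3cccc(Br)c3)cc2F)ccn1` differs from compound 2 by 3-bromophenyl in place of 4-fluorophenyl on a carbon with a double bond to nitrogen. This change touches the same aryl group that the step from compound 1 to compound 2 altered, and that step stayed within the scatter, so no movement beyond the scatter is expected in this assay. The step from compound 2 to compound 3 is estimated as a 1.1-fold lower number from compound 2 to compound 3 (0.06 log units; within the scatter). Compound 3 is expected near 900 nM, between 400 nM and 2000 nM.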

Compound 3, half-maximal inhibitory concentration: 450 nM
Compound 3: middle estimate off by 2.0-fold (0.30 log units), on the high side, within the range that was stated.
By their numbers in this assay, from the lowest: compound 3; then compounds 2 and 1 (each within the scatter of the next).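

In this assay the aryl group on the carbon with a double bond to nitrogen now moves the number beyond the scatter, with a 2.3-fold lower number from compound 2 to compound 3 (0.36 log units; beyond the scatter) and with a 4.5-fold lower number from compound 1 to compound 3 (0.65 log units; beyond the scatter) on the same place. This position therefore responds to its aryl group, which the first step within the scatter could not show, and 3-bromophenyl stands apart from both other aryl groups. Nothing on hand accounts for this difference.

Left open is whether 4-bromophenyl or 3-fluorophenyl would keep this step. Also open, going by these compounds, is how an aryl group carrying an amine or a carboxylic acid would read at this place.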